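Aryl ring change in the enone series: compound 2 to compound 4

The compounds below may be only part of what the source reports. "The series", "measured", "known", "first", "only" and "open" are said of these compounds alone.

Measured so far:
- compound 1 `O=C(/C(=C\c1ccc([N+](=O)[O-])c(O)c1)SCc1ccc(Br)cc1)c1ccc(Br)cc1`; in a functional assay on DU-145 cells (Homo sapiens) for inhibition, read by trypan blue exclusion, with a stated time of 96 h (on this read-out lower numbers stand for stronger inhibition of growth and higher numbers for weaker inhibition of growth), compound 1 gives 10000 nM
- compound 2 `O=C(/C(=C\c1c(O)cc(O)cc1O)Sc1ccccc1Br)c1ccc(Br)cc1`; in this assay compound 2 gives > 100000 nM, which is a limit of the assay and not a number
- compound 3 `O=C(/C(=C\c1c(O)cc(O)cc1O)S(=O)(=O)c1ccccc1Br)c1ccc(Br)cc1`; in this assay compound 3 gives 50000 nM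

Compound 2 stands at the limit of > 100000 nM in this assay, at which 1 of the 3 values shown sits, so only a limit and no number is known for it. For the measured compounds named here, the single measured step, an at least 2.0-fold lower number from compound 2 to compound 3 (0.30 log units; that floor lies within the scatter), alters the sulfur group on the other side of the chain, and its floor lies within the scatter. Compound 4 `O=C(/C(=C\c1ccccc1O)Sc1ccccc1Br)c1ccc(Br)cc1` differs from compound 2 by 2-hydroxyphenyl in place of 2,4,6-trihydroxyphenyl on a double-bonded chain carbon bound to a double-bonded chain carbon. Going by the values given here, no measured pair changes this ring alone; compound 1 carries another ring and another sulfur group at once, so its value cannot be assigned to either change. No step beyond the scatter is therefore expected, and the estimated step is an at least 1.2-fold lower number from compound 2 to compound 4 (0.09 log units; that floor lies within the scatter). Compound 4 is expected to give about 80000 nM, within 20000 nM to 300000 nM.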

Compound 4, concentration for 50% growth inhibition: 50000 nM
Beside the measured number, compound 4's estimate is 1.6-fold (0.20 log units) above it; low and high end bracket the measured number.
By their numbers in this assay, from the lowest: compound 1; then compounds 3 and 4 (each within the scatter of the next). At a limit, above all of these: compound 2.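

In this assay, for the compounds shown here, 2-hydroxyphenyl in place of 2,4,6-trihydroxyphenyl on a double-bonded chain carbon bound to a double-bonded chain carbon gives the first reading of this ring change alone: an at least 2.0-fold lower number from compound 2 to compound 4 (0.30 log units; that floor lies within the scatter). The figure for compound 2 is a limit of the assay and not a number: the limit of > 100000 nM in this assay, at which 1 of the 4 values shown sits. With the (2-bromophenyl)sulfanyl group kept, compound 4 gives 50000 nM, so the 2,4,6-trihydroxyphenyl ring is not needed for a measurable value in this series.

On these data alone, the true size of this step stays open, with only its floor readable. Also open, as far as these compounds go, are how 2-hydroxyphenyl behaves alongside (2-bromophenyl)sulfonyl, and whether an amine or a carboxylic acid on this ring in place of the hydroxy group would shift the number in this assay.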